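Removing one hydroxy from the 3,4-dihydroxyphenyl group

The source may hold more compounds than are shown below. What is called first, only, known or untested is meant among the compounds shown, and "the series" means these compounds.

In a functional assay on HeLa cells (Homo sapiens) for inhibition, read by trypan blue exclusion, with a stated time of 72 h (a higher number here means a weaker inhibitor of growth, a lower number a stronger inhibitor of growth), compound 1 `CCCn1c(-c2ccc(O)c(O)c2)c(C)c2cc(O)ccc21` reads > 20000 nM, which is a limit of the assay and not a number. Compound 2 `Cc1ncsc1C(=O)Oc1ccc(-c2[nH]c3ccccc3c2C)cc1` reads > 20000 nM, also a limit. For the measured compounds named here, compound 3 `Cc1c(-c2ccc(O)c(O)c2)n(CCCCOc2ccccc2)c2ccc(O)cc12` gives 10000 nM, the only actual number in the set. The rest of the set sits at one bound: the limit of > 20000 nM in this assay, at which 2 of the 3 values shown sit.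

The next compound is compound 4 `Cc1c(-c2ccc(O)cc2)n(CCCCOc2ccccc2)c2ccc(O)cc12`. It differs from compound 3 by hydrogen in place of hydroxy on an aromatic carbon, with hydrogen in place of hydroxy on an aromatic carbon, taking 3,4-dihydroxyphenyl to 4-hydroxyphenyl.

Going by the values given here, only one measured step is available, an at least 2.0-fold lower number from compound 1 to compound 3 (0.30 log units; that floor lies within the scatter), and it concerns phenoxymethyl in place of hydrogen on a saturated chain carbon. That step bears only indirectly on the present change, as it leaves the 3,4-dihydroxyphenyl group untouched. Among the compounds with values here, no measured step in the set alters that group, so the data give no size or direction for this change. The working expectation in this assay is therefore no step beyond the scatter, and a reading at the limit remains possible.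

The expected step is no change at the digits printed from compound 3 to compound 4 (within the scatter) in this estimate. For compound 4 the estimated value is 10000 nM, with an expected range from 4000 nM to 20000 nM.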

Compound 4, concentration for 50% growth inhibition: 4000 nM
For compound 4 the middle estimate is 2.5-fold (0.40 log units) above the measured one, and the stated range covers the measured number.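

In this assay, for the compounds shown here, there is a 2.5-fold lower number from compound 3 to compound 4 (0.40 log units; beyond the scatter) on removal of one hydroxy from the 3,4-dihydroxyphenyl group, the first measured change at this group. The hydroxy ortho to a hydroxy group and meta to a large group is therefore not required for the growth inhibition read here, since compound 4 has only the 4-hydroxyphenyl group and still gives a lower number than compound 3. Going by these compounds alone, the earlier step on the chain gave only a floor within the scatter, so this is the first change with a definite size and direction beyond the scatter.

Going by these compounds, whether the remaining hydroxy on the 4-hydroxyphenyl group contributes stays open, as does whether a methoxy group or a fluorine atom in its place would keep the lower number. Whether the same step would hold with the shorter chain of compound 1 also cannot be read, because some of the values shown give no number for comparison: the limit of > 20000 nM in this assay, at which 2 of the 4 values shown sit.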